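Carboxy for chloro on the aryl amine of the shared core

The source may hold more compounds than are shown below. What is called first, only, known or untested is meant among the compounds shown, and "the series" means these compounds.

Two compounds of this series have numbers. Compound 1 `CC1=NN(C(=O)c2cc3ccccc3oc2=O)C(=O)C1CNc1c(O)cc(S(=O)(=O)O)c2ccccc12` gives, in a functional assay on the whole organism for inhibition, with Rattus norvegicus as the target, read by paw edema, with stated times of 1 h and 4 h, at a dose of 0.03 mg/kg by the oral route (on this read-out lower numbers stand for less inhibition and higher numbers for more inhibition at the one dose given (going by the name of the read-out)), 21.6%. Compound 2 `CC1=NN(C(=O)c2cc3ccccc3oc2=O)C(=O)C1CNc1ccc(Cl)cc1` gives in this assay 43.5%, the higher of the two numbers, and the gap to compound 1 lies beyond the scatter. Going by the values given here, no pair differing in one place has been measured, so no step between measured compounds can be read.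

Compound 3 `CC1=NN(C(=O)c2cc3ccccc3oc2=O)C(=O)C1CNc1ccc(C(=O)O)cc1` is the next to go into this assay. It differs from compound 2 by carboxy in place of chloro on an aromatic carbon. Among the compounds with values here, nothing measured tells how this change acts here; the only acid-bearing member, compound 1, sits lowest, but it differs in more than one place. The step from compound 2 to compound 3 is expected to be a modest drop, a number 11.5 percentage points lower from compound 2 to compound 3 (beyond the scatter), with the possibility that it stays within the scatter. Compound 3 is therefore estimated at 32%, with a range from 15% to 48%.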

Compound 3, a percentage reported as inhibition, in the whole organism at one dose (the size of the read-out at that dose, not a potency): 63.6%
Beside the measured number, compound 3's estimate is 31.6 percentage points below it; measured number above the stated range.
By their numbers in this assay, from the lowest: compound 1; then compound 2; then compound 3.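

Going by these compounds alone, the change from 4-chlorophenyl to 4-carboxyphenyl on the amine of the shared core gives, in this assay, a number 20.1 percentage points higher from compound 2 to compound 3 (beyond the scatter), and this is the first step that can be read. It shows that this place on the ring, para to a large group, responds to the group it carries, and that carboxy there does not cost inhibition at the one dose given. Nothing at hand bears on why the number moves this way.

On these data alone, whether the gain is tied to the carboxylic acid itself stays open: a methyl ester, a primary amide, an amine or a longer chain ending in the acid at this same place would be needed to tell. Compound 1 differs from compound 3 in more than one place, so the gap between them cannot be assigned to any single change.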